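Swapping the Aryl Amide Group on a Shared Core

The source may hold more compounds than are shown below. What is called first, only, known or untested is meant among the compounds shown, and "the series" means these compounds.

Three measured compounds share one core and differ only in the aromatic group attached to the amide nitrogen. Compound 1 `O=C(CSc1nc(Nc2ccccc2)c2ccccc2n1)Nc1ccccc1Br` carries a 2-bromophenyl there; in a functional assay on MGC-803 cells (Homo sapiens) for inhibition, read by MTT assay, with a stated time of 72 h (on this read-out lower numbers stand for stronger inhibition and higher numbers for weaker inhibition), compound 1 gives 18600 nM, the highest of the three numbers. Compound 2 `O=C(CSc1nc(Nc2ccccc2)c2ccccc2n1)Nc1cccc(Br)c1` gives 9620 nM and compound 3 `COc1cccc(NC(=O)CSc2nc(Nc3ccccc3)c3ccccc3n2)c1` gives 10000 nM. The steps are a 1.9-fold lower number from compound 1 to compound 2 (0.29 log units; within the scatter) and a 1.9-fold lower number from compound 1 to compound 3 (0.27 log units; within the scatter), and between the other two the step is a 1.0-fold higher number from compound 2 to compound 3 (0.02 log units; within the scatter), so all three sit within the usual scatter of one another.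

Compound 4 `O=C(CSc1nc(Nc2ccccc2)c2ccccc2n1)Nc1ccc([N+](=O)[O-])cc1` has not yet been measured. Its change from compound 1 is 4-nitrophenyl in place of 2-bromophenyl on an amide-type nitrogen. Within the data shown here, no measured step involves a nitro group, so the only guide is that the two measured swaps of the aromatic group on this nitrogen moved the number very little. Compound 4 is therefore expected to give a number close to those already seen, a 1.7-fold lower number from compound 1 to compound 4 (0.23 log units; within the scatter). The estimate for compound 4 in this assay is 11000 nM, expected to lie between 4000 nM and 30000 nM.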

Compound 4, half-maximal inhibitory concentration: > 50000 nM
Compound 4: only a limit was reported; the forecaster's own chance of this, stated with the estimate: 5%; at least 4.5-fold (0.65 log units) between middle value and limit.
By their numbers in this assay, from the lowest: compounds 2, 3 and 1 (each within the scatter of the next). At a limit, above all of these: compound 4.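

In this assay compound 4 gives only a limit, not a number: the limit of > 50000 nM in this assay, at which 1 of the 4 values shown sits. The earlier swaps on this nitrogen all stayed within the scatter, but this one goes beyond it in every comparison: an at least 2.6-fold higher number from compound 1 to compound 4 (0.42 log units; beyond the scatter), an at least 5.0-fold higher number from compound 3 to compound 4 (0.69 log units; beyond the scatter) and an at least 5.1-fold higher number from compound 2 to compound 4 (0.71 log units; beyond the scatter). The aromatic group on the amide-type nitrogen can therefore matter after all, and the shared core does not keep its inhibition with every group placed there.

The compounds shown cannot separate the nitro group itself from its place on the ring, since the 4-nitrophenyl group differs from the others in both. On these data alone, how an amine or a carboxylic acid on this same ring would read also remains open.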